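From a Chlorophenyl Ketone Arm to a Nitrophenoxy Arm

A few compounds are considered here, and "the series" means these few. Any claim that something is new, unique, unknown or untested is made for them only; others in the source may bear on it.

Three compounds share one core and differ only in the arm attached to the amide carbonyl. Compound 1 `Cc1ccc(CC(C)C(=O)N2CCN(c3ccc(C(F)(F)F)cc3[C@@H](N)CC(C)C)CC2)cc1C` gives 240 nM in an assay on HEK293 cells for displacement of a labelled ligand from Melanocortin receptor 4 (Homo sapiens); a lower number here means a stronger inhibitor, a higher number a weaker inhibitor. Compound 2 `CC(C)C[C@H](N)c1cc(C(F)(F)F)ccc1N1CCN(C(=O)COc2ccc3ccccc3c2)CC1` gives 2000 nM in this assay, and compound 3 `CC(C)C[C@H](N)c1cc(C(F)(F)F)ccc1N1CCN(C(=O)CCC(=O)c2ccc(Cl)cc2)CC1` gives 820 nM. Compound 3 therefore stands second highest of the three numbers, with a 2.4-fold lower number from compound 2 to compound 3 (0.39 log units; beyond the scatter) and a 3.4-fold higher number from compound 1 to compound 3 (0.53 log units; beyond the scatter).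

Compound 4 `CC(C)C[C@H](N)c1cc(C(F)(F)F)ccc1N1CCN(C(=O)COc2ccc([N+](=O)[O-])cc2)CC1` has not yet been measured. Its change from compound 3 is 4-nitrophenoxy in place of ((4-chlorophenyl)carbonyl)methyl on a saturated chain carbon bound to a carbonyl carbon. Among the compounds with values here, the step that bears most on this is the one between compound 2 and compound 3, where an aryl ether arm gave the higher number, a 2.4-fold lower number from compound 2 to compound 3 (0.39 log units; beyond the scatter). Compound 4 again carries an aryl ether arm, so a move back toward the higher number of compound 2 is expected, though the ring itself is different and no direct comparison of the two ethers exists. The expected step is a 2.2-fold higher number from compound 3 to compound 4 (0.34 log units; beyond the scatter). Compound 4 is estimated at 1800 nM, within a range from 700 nM to 4500 nM.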

Compound 4, inhibition constant: 3100 nM
Estimate against measurement, compound 4: 1.7-fold (0.24 log units) below; measured number inside the range.
By their numbers in this assay, from the lowest: compound 1; then compound 3; then compounds 2 and 4 (each within the scatter of the next).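

In this assay, 4-nitrophenoxy in place of ((4-chlorophenyl)carbonyl)methyl gives a 3.8-fold higher number from compound 3 to compound 4 (0.58 log units; beyond the scatter), so the ketone arm of compound 3 now sits apart from two aryl ether arms rather than one. The ring on the ether oxygen makes no readable difference so far: 4-nitrophenyl in place of naphthalen-2-yl gives a 1.6-fold higher number from compound 2 to compound 4 (0.19 log units; within the scatter), so these two quite different rings cannot be told apart here. The branched arm of compound 1 remains well apart from this ether arm, with a 13-fold higher number from compound 1 to compound 4 (1.11 log units; beyond the scatter), a large step.

Nothing available here explains any of these steps. As far as these compounds go, it remains open whether a 4-chlorophenoxy arm would fall with the two ethers or with compound 3, which would separate the effect of the chlorine from that of the ketone.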